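Swapping the Aryl Group: Dichlorophenyl Out, tert-Butylphenyl In

A few compounds are considered here, and "the series" means these few. Any claim that something is new, unique, unknown or untested is made for them only; others in the source may bear on it.

Compound 1 `CCCS(=O)(=O)Nc1ccc(F)c(C(=O)c2n[nH]c3ncc(-c4ccc(OC)cc4)cc23)c1F`: 4.2% in an assay for binding affinity to dual specificity mitogen-activated protein kinase kinase 4 (Homo sapiens), read by KINOMEscan, tested at 100 nM; on this read-out lower numbers stand for a stronger effect and higher numbers for a weaker effect at the one concentration tested
Compound 2 `CCCS(=O)(=O)Nc1ccc(F)c(C(=O)c2n[nH]c3ncc(-c4cc(Cl)cc(Cl)c4)cc23)c1F`: 73%

Compound 2 gives the higher of the two numbers, so on this read-out it is the weaker binder of the two. For the measured compounds named here, the only measured step is a number 68.8 percentage points higher from compound 1 to compound 2 (beyond the scatter), which shows that exchanging the aryl group at this position can move the read-out a long way.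

Compound 3 `CCCS(=O)(=O)Nc1ccc(F)c(C(=O)c2n[nH]c3ncc(-c4ccc(C(C)(C)C)cc4)cc23)c1F` differs from compound 2 by 4-(tert-butyl)phenyl in place of 3,5-dichlorophenyl on an aromatic carbon. Going by the values given here, no measured step covers a 4-(tert-butyl)phenyl group, so the expectation can rest only on the fact that compound 1, carrying a 4-methoxyphenyl group, gave 4.2% while the 3,5-dichlorophenyl in compound 2 gave 73%. A step downward is therefore expected, a number 58 percentage points lower from compound 2 to compound 3 (beyond the scatter), though its size is uncertain. Compound 3 is estimated at 15%, with a range from 2% to 55%.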

Compound 3, a percentage reported as activity, at one concentration (the size of the read-out at that concentration, not a potency): 46%
Beside the measured number, compound 3's estimate is 31 percentage points below it, and the stated range covers the measured number.
By their numbers in this assay, from the lowest: compound 1; then compound 3; then compound 2.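

In this assay, the change to 4-(tert-butyl)phenyl gives a number 27 percentage points lower from compound 2 to compound 3 (beyond the scatter), so a group other than 4-methoxyphenyl can also improve on 3,5-dichlorophenyl at this aromatic carbon, though only part of the way. The step of a number 41.8 percentage points higher from compound 1 to compound 3 (beyond the scatter) shows something further: with the phenyl ring kept and only the group on it exchanged, tert-butyl in place of methoxy changes the read-out by a large amount, so the result depends on that group and not merely on having a phenyl ring here. No measurement shown explains either difference.

Still open, on these data alone, is whether an ethoxy, a hydroxyl or an amine on the same phenyl ring would give a reading close to that of compound 1. Also open, as far as these compounds go, is whether a single chlorine would behave like the two in compound 2.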